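A few compounds are considered here, and "the series" means these few. Any claim that something is new, unique, unknown or untested is made for them only; others in the source may bear on it.

Compound 1 `Cc1nc(S(C)(=O)=O)ccc1Oc1ncnc(OC2CCN(C(=O)OC3CCC3)CC2)c1F`: 81%
Compound 2 `Cc1nc(S(C)(=O)=O)ccc1Oc1ncnc(OC2CCN(C(=S)OC(C)C)CC2)c1F`: 47%
Compound 3 `Cc1nc(S(C)(=O)=O)ccc1Oc1ncnc(OC2CCN(C(=O)C(F)(F)F)CC2)c1F`: 76%

In a functional assay on isolated protein for inhibition of Glucose-dependent insulinotropic receptor (Rattus norvegicus), read by HTRF and cAMP accumulation (a higher number here means a larger maximal response, a lower number a smaller maximal response), compound 3 stands second highest of the three measured numbers. Its nearest neighbour is compound 1, since the step of a number 5 percentage points lower from compound 1 to compound 3 (within the scatter) lies within the scatter, while the step of a number 29 percentage points higher from compound 2 to compound 3 (beyond the scatter) is beyond it. Compound 4 `Cc1nc(S(C)(=O)=O)ccc1Oc1ncnc(OC2CCN(C(=O)c3nc(C(C)(C)F)no3)CC2)c1F` differs from compound 3 in one place: a group of 9 heavy atoms (5 carbon, 2 nitrogen, 1 oxygen, 1 fluorine; one five-membered aromatic ring with 3 hetero atoms) in place of a group of 4 heavy atoms (1 carbon, 3 fluorine; no ring), on a carbonyl carbon. For the measured compounds named here, the only measured exchange on the carbonyl carbon, the step of a number 5 percentage points lower from compound 1 to compound 3 (within the scatter), left this assay essentially unchanged; the larger step of a number 29 percentage points higher from compound 2 to compound 3 (beyond the scatter) concerned an exchange on the amine nitrogen, a different kind of change. Going by the values given here, no measured step trades a trifluoromethyl for an aromatic ring on the carbonyl carbon, so the expectation rests on compound 1 and compound 3 alone. The step of a number 4 percentage points lower from compound 3 to compound 4 (within the scatter) is therefore expected to stay within the scatter. Compound 4 is estimated at 72%, with a range from 48% to 90%.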

Compound 4, largest response reached (reported as efficacy), in percent of the reference or control that the assay uses: 84%
For compound 4 the middle estimate is 12 percentage points below the measured one; low and high end bracket the measured number.
By their numbers in this assay, from the lowest: compound 2; then compounds 3, 1 and 4 (each within the scatter of the next).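

On the carbonyl carbon, the group with a five-membered aromatic ring replaces trifluoromethyl in the step of a number 8 percentage points higher from compound 3 to compound 4 (within the scatter) and cyclobutyloxy in the step of a number 3 percentage points higher from compound 1 to compound 4 (within the scatter) in this assay. Three groups that differ widely in size and ring content therefore give numbers within the scatter of each other on this carbon, whereas the step of a number 37 percentage points higher from compound 2 to compound 4 (beyond the scatter) sets compound 2 clearly apart. Nothing available explains this result.

From the compounds shown here alone, it remains open how an amine or a carboxylic acid on the carbonyl carbon would read in this assay. The compounds shown also do not reveal whether sulfur in place of the carbonyl oxygen alone would lower the number.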